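Replacing an ethyl with a cyclopropylcarbamoyl on the side chain

The source may report more compounds than this note shows. Statements on the series, on what has been measured and on what is new or still open speak of the compounds shown alone.

Of the compounds shown here, two sharing one core have been measured in an assay for inhibition of RAC-alpha serine/threonine-protein kinase (Homo sapiens), read by HTRF, with a stated time of 1 h; a higher number here means a weaker inhibitor, a lower number a stronger inhibitor. Compound 1 `Cn1ncc(Cl)c1-c1cc(C(=O)N[C@@H]2CN[C@H](CCn3cncn3)C[C@H]2c2ccc(Cl)c(Cl)c2)oc1Cl` gives 4.47 nM. Compound 2 `CCC[C@@H]1C[C@@H](c2ccc(Cl)c(Cl)c2)[C@H](NC(=O)c2cc(-c3c(Cl)cnn3C)c(Cl)o2)CN1` gives 10.4 nM, which is the higher of the two numbers. For the measured compounds named here, the only step between them, a 2.3-fold higher number from compound 1 to compound 2 (0.37 log units; beyond the scatter), shows that removing the triazolyl ring from the side chain and leaving a plain alkyl made the inhibitor somewhat weaker.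

Compound 3 `Cn1ncc(Cl)c1-c1cc(C(=O)N[C@@H]2CN[C@H](CC(=O)NC3CC3)C[C@H]2c2ccc(Cl)c(Cl)c2)oc1Cl` changes the same side chain of compound 2 again: cyclopropylcarbamoyl in place of ethyl on a saturated chain carbon bound to a saturated ring carbon. The step from compound 1 to compound 2 is the one that bears on this change, since it too exchanged a plain alkyl end for a group with a ring and heteroatoms, and it was modest in size. A similar modest movement, this time towards a lower number, is therefore expected, a 1.7-fold lower number from compound 2 to compound 3 (0.24 log units; within the scatter). Compound 3 is estimated at 6 nM, within a range from 2 nM to 20 nM.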

Compound 3, half-maximal inhibitory concentration: 3.95 nM
Compound 3: middle estimate off by 1.5-fold (0.18 log units), on the high side; the range from low to high includes it.
By their numbers in this assay, from the lowest: compounds 3 and 1 (each within the scatter of the next); then compound 2.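

Putting cyclopropylcarbamoyl in place of ethyl at this position gives a 2.6-fold lower number from compound 2 to compound 3 (0.42 log units; beyond the scatter), so a second, quite different ring-bearing group also stands apart from the plain alkyl chain of compound 2. The two ring-bearing side chains cannot be told apart in this assay, with a 1.1-fold lower number from compound 1 to compound 3 (0.05 log units; within the scatter), so the exact identity of the group at the end of the chain makes no visible difference between these two. No measurement available here explains why either group differs from the plain alkyl chain.

Going by these compounds, what remains open is which part of the cyclopropylcarbamoyl group matters: the three-membered ring, the carbonyl or the amide hydrogen. Side chains ending in a plain cyclopropyl, a primary amide or a carboxylic acid would help to separate these parts.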